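The compounds below may be only part of what the source reports. "The series", "measured", "known", "first", "only" and "open" are said of these compounds alone.

Compound 1 `S=C(N/N=C/c1ccc2ccccc2n1)Nc1cccc(Cl)c1` is a thiosemicarbazone built on a quinoline aldehyde-derived core. Among the measured compounds shown here, in a functional assay on SGC-7901 cells (Homo sapiens) for antiproliferative activity, read by sulforhodamine B assay, with a stated time of 72 h (on this read-out higher numbers stand for weaker inhibition and lower numbers for stronger inhibition), compound 1 gives 61300 nM, the highest number among the three compounds measured so far. Its nearest neighbour is compound 2 `CC(C)c1cccc(C(C)C)c1NC(=S)N/N=C/c1ccc2ccccc2n1`, which carries a crowded aryl group on the thioamide nitrogen and in this assay gives 23500 nM, a lower number that lies beyond the scatter of repeated measurements. Far removed from both is compound 3 `CN(C)C(=S)N/N=C/c1ccc2ccccc2n1`, in which the thioamide nitrogen bears two methyl groups; in this assay compound 3 gives 30 nM, the strongest inhibition of the set by a wide margin.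

The step under consideration leads from compound 1 to compound 4 `S=C(NCc1ccccc1)N/N=C/c1ccc2ccccc2n1`. The change is benzyl in place of 3-chlorophenyl on an amide-type nitrogen. For the measured compounds named here, no measured pair shows this exact exchange, so there is no direct precedent to lean on. What the measured compounds do show is that both aryl-substituted thioamide nitrogens give weak inhibition, while the disubstituted compound 3 stands apart. Compound 4 keeps a single substituent on that nitrogen, so the expectation is for a value closer to compound 1 and compound 2 than to compound 3, with a modest shift toward stronger inhibition that may not exceed the scatter, expressed as a 3.1-fold lower number from compound 1 to compound 4 (0.49 log units; beyond the scatter). Compound 4 is therefore estimated at 20000 nM in this assay, within a range from 3000 nM to 80000 nM.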

Compound 4, half-maximal inhibitory concentration: 53700 nM
Beside the measured number, compound 4's estimate is 2.7-fold (0.43 log units) below it; the measured number falls inside the stated range.
By their numbers in this assay, from the lowest: compound 3; then compound 2; then compounds 4 and 1 (each within the scatter of the next).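

In this assay, among the compounds shown here, placing benzyl in place of 3-chlorophenyl on the amide-type nitrogen gives a step of a 1.1-fold lower number from compound 1 to compound 4 (0.06 log units; within the scatter) and so provides the first direct reading at this position. The two groups differ in where their seven heavy atoms lie and in the chlorine that benzyl lacks, yet the two values stand within the scatter of each other, so this exchange cannot be told apart from repeated measurement. For the compounds shown here, with only this one step at the position, nothing measured here explains why the two compounds read alike.

The compounds shown leave open whether a plain alkyl chain such as ethyl or butyl on this nitrogen, with no aromatic ring at all, would read like compound 1 and compound 4 or move toward the far lower number of compound 3. They also leave open whether a longer chain ending in a phenyl ring, such as phenethyl, or a cyclic amine such as morpholine at this nitrogen would depart from these values.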